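Ethyl at the Core of Compound 3

A few compounds are considered here, and "the series" means these few. Any claim that something is new, unique, unknown or untested is made for them only; others in the source may bear on it.

Compound 3 `COc1cc2ncnc(N3CCN(c4ccccc4OC)CC3)c2cc1OC` stands only at a limit among the numbers shown. In an in vitro assay on U2OS cells for agonist activity at neurotensin receptor type 2 (Homo sapiens), read by reporter gene assay and beta-arrestin recruitment (a higher number here means that more compound is needed for the effect, a lower number that less compound is needed), compound 3 gives > 80000 nM, which is a limit and not a number. Compound 1 `COc1cc2nc(C3CCC3)nc(N3CCN(c4ccccc4C)CC3)c2cc1OC` gives > 80000 nM, also a limit. Compound 2 `COc1cc2nc(C3CCC3)nc(N3CCN(c4ccccn4)CC3)c2cc1OC` gives > 80000 nM, likewise a limit. The step that the two limits leave unreadable from compound 1 to compound 2 therefore cannot be read. The same limit recurs throughout: the limit of > 80000 nM in this assay, at which 3 of the 3 values shown sit. Compound 4 `CCc1nc(N2CCN(c3ccccc3OC)CC2)c2cc(OC)c(OC)cc2n1` differs from compound 3 by ethyl in place of hydrogen on an aromatic carbon. For the measured compounds named here, no measured step bears directly on this change, and since every value shown sits at the limit, no size or direction can be drawn from them; a further limit is the most probable outcome in this assay. Compound 4 is therefore expected to give 100000 nM, within 30000 nM to 300000 nM. The expected step is a step that the limit leaves unreadable from compound 3 to compound 4.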

Compound 4, half-maximal effective concentration: > 80000 nM
Compound 4: a limit, no number; the forecaster's own chance of this, stated with the estimate: 85%; the middle value does not contradict the limit.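

No new step can be read between compound 3 and compound 4, because both stand at a limit and give no number: the limit of > 80000 nM in this assay, at which 4 of the 4 values shown sit. The compounds shown leave open what structure, if any, would give a number in this assay.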